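Compound 2 to compound 4: both bromo groups leave

This account rests on a few compounds, and the source may have more. Where it says the series, first, only, none or still open, it means among the compounds named here.

In a physicochemical assay for lipophilicity (a higher number here means a more lipophilic compound, a lower number a more polar compound), compound 2 (`COc1cc(Cn2c(=O)cc(N3CCC[C@@H](N)C3)n(Cc3cc(F)ccc3C#N)c2=O)c(Br)c(Br)c1OC`) gives 4.32 and stands second highest of the three measured compounds. Compound 3 (`COc1c(Br)c(Br)c(Cn2c(=O)cc(N3CCC[C@@H](N)C3)n(Cc3cc(F)ccc3C#N)c2=O)c(Br)c1OC`) gives 5.15 and compound 1 (`CC#CCn1c(N2CCC[C@@H](N)C2)cc(=O)n(Cc2cc(F)cc(F)c2)c1=O`) gives 2.12 on the same scale. Compound 4 (`N#Cc1ccc(F)cc1Cn1c(N2CCC[C@@H](N)C2)cc(=O)n(Cc2cc(F)cc(F)c2)c1=O`) has not yet been measured. The change 3,5-difluorophenyl in place of 2,3-dibromo-4,5-dimethoxyphenyl on a saturated chain carbon bound to an aromatic nitrogen puts 3,5-difluorophenyl in place of 2,3-dibromo-4,5-dimethoxyphenyl on a saturated chain carbon bound to an aromatic nitrogen. Among the compounds with values here, one measured step bears on it directly: a number 0.83 log units higher from compound 2 to compound 3 (beyond the scatter) for a bromo in place of hydrogen on an aromatic carbon, a modest step beyond the scatter. Here both bromo groups leave, and no measured step covers the methoxy groups or the fluorines. Compound 1 at 2.12 also carries 3,5-difluorophenyl, though it differs elsewhere. Read in reverse for both bromo groups, that single step points to a larger fall in this assay and the expected change is a number 1.42 log units lower from compound 2 to compound 4 (beyond the scatter) overall. For compound 4 the estimated value is 2.9 with an expected range from 2.4 to 3.4 on this reasoning.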

Compound 4, partition coefficient: 3.23
The estimate for compound 4 lay 0.33 log units below the measured number, and the stated range covers the measured number.
By their numbers in this assay, from the lowest: compound 1; then compound 4; then compound 2; then compound 3.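

In this assay, the whole aryl group at this place now has a measured step: 3,5-difluorophenyl in place of 2,3-dibromo-4,5-dimethoxyphenyl on a saturated chain carbon bound to an aromatic nitrogen gives a number 1.09 log units lower from compound 2 to compound 4 (beyond the scatter). With 3,5-difluorophenyl common to both compounds, 2-cyano-5-fluorophenyl in place of prop-1-yn-1-yl on a saturated chain carbon bound to an aromatic nitrogen gives a number 1.11 log units higher from compound 1 to compound 4 (beyond the scatter), so the read-out moves beyond the scatter with a change at either place. No measured evidence accompanies these steps to explain them.

The step from 2,3-dibromo-4,5-dimethoxyphenyl to 3,5-difluorophenyl changes the bromo, methoxy and fluoro groups together, and the compounds shown do not separate their shares. They also leave open what an unsubstituted phenyl ring or a phenyl ring bearing a carboxylic acid would give at this place.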